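The compounds below may be only part of what the source reports. "The series", "measured", "known", "first", "only" and "open" are said of these compounds alone.

Measured so far:
- compound 1 `C=CCOc1ccc(C(=O)Nc2cccc(Cl)n2)cc1`: > 100000 nM
- compound 2 `CCCCNc1cccc(NC(=O)c2ccc(OCCC)cc2)n1`: 77800 nM

In an in vitro assay on HEK-tsA201 cells for antagonist activity at Neuronal acetylcholine receptor; alpha3/beta4 (Homo sapiens), read by fluorescence and calcium flux (on this read-out higher numbers stand for weaker inhibition and lower numbers for stronger inhibition), compound 2 gives 77800 nM, the only plain number among the two results shown. For compound 1 the assay reports only a limit, > 100000 nM, which is a boundary of the measurement rather than a number. Compound 3 `CCCOc1ccc(C(=O)Nc2cccc(Nc3ccc(F)cc3)n2)cc1` has not been measured; it differs from compound 2 by 4-fluorophenyl in place of butyl on a nitrogen on an aromatic ring. Among the measured compounds shown here, no measured pair shows a step of this kind, so the size and direction of the change remain open. Compound 3 is expected to stay weak, with an estimated step of a 1.6-fold lower number from compound 2 to compound 3 (0.19 log units; within the scatter) and a value of about 50000 nM, spanning 10000 nM to 300000 nM.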

Compound 3, half-maximal inhibitory concentration: > 100000 nM
Compound 3: a limit, no number; the forecaster's own chance of this, stated with the estimate: 40%; middle value at least 2.0-fold (0.30 log units) from the limit.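

In this assay, the first step read at this position, butylamino to (4-fluorophenyl)amino, is an at least 1.2-fold higher number from compound 2 to compound 3 (0.10 log units; that floor lies within the scatter). An aromatic ring on this nitrogen therefore brings no stronger inhibition than the butyl chain. The value of compound 3 is a limit and not a number, so that step is only a floor, and its true size cannot be read because the results crowd at the top of the range: the limit of > 100000 nM in this assay, at which 2 of the 3 values shown sit.

Going by these compounds, whether a methyl group, a longer chain or a chain ending in an amine on this nitrogen would give stronger inhibition stays open.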